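Working notes: from compound 1 toward compound 3

This account rests on a few compounds, and the source may have more. Where it says the series, first, only, none or still open, it means among the compounds named here.

The series is read in a functional assay on SGC-7901 cells (Homo sapiens) for antiproliferative activity, read by MTT assay, with a stated time of 24 h; on this read-out higher numbers stand for weaker inhibition and lower numbers for stronger inhibition. Compound 1 `Cc1cccc(NNC(=O)c2ccccc2NS(=O)(=O)c2cnc(O)nc2O)c1` is the anchor. In this assay compound 1 reports only the limit > 20000 nM, not a resolved number. Compound 2 `O=C(NNC(=O)c1ccccc1F)c1cccc(NS(=O)(=O)c2cnc(O)nc2O)c1` is the other member measured. In this assay compound 2 likewise reports only the limit > 20000 nM, again not a number. Within the data shown here, compound 1 thus stands at the ceiling of what has been measured, with no figure beside it to rank against; the whole of the evidence on the series so far is the limit of > 20000 nM in this assay, at which 2 of the 2 values shown sit.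

Compound 3 `O=C(NNC(=O)c1ccccc1NS(=O)(=O)c1cnc(O)nc1O)c1ccccc1F` has not yet been measured in this assay. Against compound 1 it differs in one place ((2-fluorophenyl)carbonyl in place of 3-methylphenyl on an amine nitrogen). Among the measured compounds shown here, no step between measured compounds exists, so the size of the move cannot be taken from a measured pair. Because compound 1 reports only the limit > 20000 nM, no change beyond the scatter is expected here. The expected step is a step that the limit leaves unreadable from compound 1 to compound 3. Compound 3 is expected to give about 40000 nM, within 12000 nM to 150000 nM.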

Compound 3, half-maximal inhibitory concentration: > 20000 nM
Compound 3: only a limit was reported; the forecaster's own chance of this, stated with the estimate: 85%; the middle value is on the limit's open side.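

In this assay compound 3 gives > 20000 nM, a limit and not a number. Among these compounds, compound 1 and compound 3 both report only limits, and no step between them can be read. The compounds shown leave open whether any change to this series gives a resolved value, and how large any such change would be: the limit of > 20000 nM in this assay, at which 3 of the 3 values shown sit.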